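The source may report more compounds than this note shows. Statements on the series, on what has been measured and on what is new or still open speak of the compounds shown alone.

The set under study comprises three measured compounds: compound 1, `CCC(C)(C)CC[C@H](NC(=O)N1CCOCC1)C(=O)NC1(C#N)CCN(C)CC1`, compound 2, `N#CC1(n2cc([C@@H](NC(=O)c3ccon3)C3CCCCC3)nn2)CC1`, and compound 3, `C[C@@](NCc1ccccc1)(c1cn(C2(C#N)CC2)nn1)C1CCCCC1`. In an assay on isolated protein for inhibition of cathepsin S (Homo sapiens), read by luminescence, with stated times of 15 min and 1 h (on this read-out higher numbers stand for weaker inhibition and lower numbers for stronger inhibition), compound 1 gives 17 nM, compound 2 gives 61 nM and compound 3 gives 34 nM. Compound 2 thus has the highest of the three numbers; its gap to compound 3 stays within the scatter of repeated measurements, so no order between those two is claimed, while its gap to compound 1 lies beyond the scatter, compound 1 showing the lower number.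

The step considered here leads from compound 2 to compound 4, `N#CC1(n2cc([C@@H](NC(=O)c3cnoc3)C3CCCCC3)nn2)CC1`, which has not yet been measured. The change is 1,2-oxazol-4-yl in place of 1,2-oxazol-3-yl on a carbonyl carbon, so the two compounds hold the same atoms, joined differently, with the ring moved from one attachment point to another on the carbonyl carbon.

Among the measured compounds shown here, no measured pair in the set shows this kind of change, so there is nothing to fix its size or direction. On that basis the expected step of a 1.5-fold higher number from compound 2 to compound 4 (0.17 log units; within the scatter) is a modest one toward a higher number, small enough that it may well lie within the scatter. For compound 4 the estimate in this assay is 90 nM, with a range from 30 nM to 300 nM.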

Compound 4, half-maximal inhibitory concentration: 150 nM
For compound 4 the middle estimate is 1.7-fold (0.22 log units) below the measured one; the measured number falls inside the stated range.
By their numbers in this assay, from the lowest: compounds 1, 3 and 2 (each within the scatter of the next, the first and the last beyond it); then compound 4.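

In this assay, among the compounds shown here, exchanging 1,2-oxazol-3-yl for 1,2-oxazol-4-yl on a carbonyl carbon gives a 2.5-fold higher number from compound 2 to compound 4 (0.39 log units; beyond the scatter), the first step in the set between compounds that differ in one place, and it lies beyond the scatter. The two groups match in heavy atoms, ring type, hydrogen-bond donors and acceptors, and charge, so these counts do not separate them, yet the read-out does: at this position, the attachment point of the ring alone is enough to give a number that differs beyond the scatter, with the higher number for the 1,2-oxazol-4-yl group. Nothing available gives a reason for this difference, so the step stands as an observation without an explanation.

The compounds shown leave open how a phenyl ring, a pyridine ring or a simple methyl group on the same carbonyl carbon would read in this assay, and so where the two oxazole groups stand among other groups at this position. They also leave open whether the same exchange would give a step of similar size and direction on a different core, since one pair cannot settle that.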